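Acetamido for Chloro on a Boronic Acid Antiproliferative

The source may report more compounds than this note shows. Statements on the series, on what has been measured and on what is new or still open speak of the compounds shown alone.

Measured compounds:
- compound 1, `CC(C)C[C@H](NC(=O)CSc1cc(NS(=O)(=O)c2ccccc2)c2ccccc2c1O)B(O)O`: 4160 nM
- compound 2, `CC(C)C[C@H](NC(=O)CSc1cc(NS(=O)(=O)c2ccc(Cl)cc2)c2ccccc2c1O)B(O)O`: 10400 nM

Both compounds were tested in a functional assay on MCF7 cells (Homo sapiens) for antiproliferative activity, read by sulforhodamine B assay, with a stated time of 72 h; on this read-out lower numbers stand for stronger inhibition and higher numbers for weaker inhibition. Among the measured compounds shown here, compound 2 stands at the higher of the two numbers: compound 1 gives 4160 nM, and the one measured step, a 2.5-fold higher number from compound 1 to compound 2 (0.40 log units; beyond the scatter), lies beyond the usual scatter, so compound 2 is the weaker of the pair.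

Compound 3, `CC(=O)Nc1ccc(S(=O)(=O)Nc2cc(SCC(=O)N[C@@H](CC(C)C)B(O)O)c(O)c3ccccc23)cc1`, is not yet measured. It differs from compound 2 in one place: acetamido in place of chloro on an aromatic carbon.

For the measured compounds named here, only the single step from compound 1 to compound 2 bears on this, and only loosely, since it swaps hydrogen for chloro while the new step removes the chloro and puts acetamido at the same place on the six-membered aromatic ring, para to a large group. Nothing measured here shows what an acetamido group does. The size of a 2.5-fold higher number from compound 1 to compound 2 (0.40 log units; beyond the scatter) suggests that changes at this position move the number modestly, in either direction. The estimate for compound 3 is therefore placed near compound 2, with a wide range, and the expected step of a 1.5-fold lower number from compound 2 to compound 3 (0.17 log units; within the scatter) is small. Compound 3 is expected to give about 7000 nM, between 2000 nM and 25000 nM.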

Compound 3, half-maximal inhibitory concentration: 8660 nM
Estimate against measurement, compound 3: 1.2-fold (0.09 log units) below; the range from low to high includes it.
By their numbers in this assay, from the lowest: compound 1; then compounds 3 and 2 (each within the scatter of the next).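

In this assay, replacing chloro with acetamido adds one hydrogen-bond donor and one hydrogen-bond acceptor at this place on the ring, yet the number does not move beyond the usual scatter (a 1.2-fold lower number from compound 2 to compound 3 (0.08 log units; within the scatter)). Hydrogen at the same place now has two comparisons instead of one: acetamido also differs from it beyond the scatter (a 2.1-fold higher number from compound 1 to compound 3 (0.32 log units; beyond the scatter)), and on the same side as chloro, so compound 1 holds the lowest number and is the strongest of these three. Nothing available here explains why these two different groups give matching results.

As far as these compounds go, three compounds cannot show whether this holds for every group at this place, so it remains open whether an amine, a carboxylic acid or a longer chain such as 4-butyl would also give a higher number than hydrogen, or would match or improve on it. Also open, from the compounds shown here alone, is whether the small gap between chloro and acetamido would persist if the rest of the core of compound 1 were changed.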